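A few compounds are considered here, and "the series" means these few. Any claim that something is new, unique, unknown or untested is made for them only; others in the source may bear on it.

Measured in a functional assay for inhibition, with Homo sapiens as the target; a higher number here means a weaker inhibitor, a lower number a stronger inhibitor:
- compound 1 `O=C(NC[C@H](NS(=O)(=O)c1ccccc1)C(=O)O)c1cc2cc(OCCC3CCNCC3)ccc2[nH]1`: 8 nM
- compound 2 `O=C(NC[C@H](NS(=O)(=O)c1ccccc1)C(=O)O)c1cc2cc(OCc3ccncc3)ccc2[nH]1`: 280 nM
- compound 3 `Nc1cc(COc2ccc3[nH]c(C(=O)NC[C@H](NS(=O)(=O)c4ccccc4)C(=O)O)cc3c2)ccn1`: 45 nM

Compound 3 holds the second highest of the three numbers in this assay. On one side lies a 5.6-fold higher number from compound 1 to compound 3 (0.75 log units; beyond the scatter), and on the other lies a 6.2-fold lower number from compound 2 to compound 3 (0.79 log units; beyond the scatter).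

The next structure is compound 4 `O=C(NC[C@H](NS(=O)(=O)c1ccccc1)C(=O)O)c1cc2cc(OCCn3ccnc3)ccc2[nH]1`. The change is (1H-imidazol-1-yl)methyl in place of 2-aminopyridin-4-yl on a saturated chain carbon bound to an oxygen on an aromatic ring. Cut one bond further out, this reads (2-aminopyridin-4-yl)methoxy to 2-(1H-imidazol-1-yl)ethoxy.

Within the data shown here, no measured compound carries the entering group, so no step measures this change directly. All three measured steps fall at this same place and all lie beyond the scatter: the large 35-fold higher number from compound 1 to compound 2 (1.54 log units; beyond the scatter), the modest 5.6-fold higher number from compound 1 to compound 3 (0.75 log units; beyond the scatter) and the modest 6.2-fold lower number from compound 2 to compound 3 (0.79 log units; beyond the scatter). The last is the closest guide, since the entering group has no amino group and compound 2, also without one, gives 280 nM.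

A modest step to a higher number is therefore expected, estimated as a 4.4-fold higher number from compound 3 to compound 4 (0.65 log units; beyond the scatter). The estimated value for compound 4 is 200 nM, with an expected range of 50 nM to 800 nM.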

Compound 4, half-maximal inhibitory concentration: 45 nM
Beside the measured number, compound 4's estimate is 4.4-fold (0.65 log units) above it, and the stated range ends above it.
By their numbers in this assay, from the lowest: compound 1; then compounds 3 and 4 (each within the scatter of the next); then compound 2.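

In this assay, among these compounds, no change at the digits printed from compound 3 to compound 4 (within the scatter) shows that the 2-aminopyridin-4-yl group is not the only group at this position that gives this reading: 2-(1H-imidazol-1-yl)ethoxy, with 0 hydrogen-bond donors in the entering group, does the same, so the amino group's hydrogen-bond donor is not required across this set. Measured from the plain pyridine, a 6.2-fold lower number from compound 2 to compound 4 (0.79 log units; beyond the scatter), a step of the same printed size as a 6.2-fold lower number from compound 2 to compound 3 (0.79 log units; beyond the scatter), so two different changes at this place now lead away from the number of compound 2, while a 5.6-fold higher number from compound 1 to compound 4 (0.75 log units; beyond the scatter) keeps the piperidine-bearing compound 1 as the lowest number in the series. No measurement at hand explains why these two groups read alike.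

The step from compound 3 to compound 4 alters the ring and the chain together, from (2-aminopyridin-4-yl)methoxy to 2-(1H-imidazol-1-yl)ethoxy, so the contribution of each remains unseparated. A 2-(pyridin-4-yl)ethoxy group or a (1H-imidazol-1-yl)-bearing propoxy chain would help to show whether the ring type or the chain length governs the reading in this assay.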